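A thiazole exchange starting from a limit

This account rests on a few compounds, and the source may have more. Where it says the series, first, only, none or still open, it means among the compounds named here.

Compound 1 `Cc1cc(Cl)c(-c2cn(C)cn2)cc1NC(=O)c1ccc(OCc2ccccn2)cc1`: 20000 nM
Compound 2 `Cc1cc(Cl)c(-c2cn(C)c(C)n2)cc1NC(=O)c1ccc(OCc2ccccn2)cc1`: < 1000 nM (a limit)
Compound 3 `Cc1csc(-c2cc(NC(=O)c3ccc(OCc4ccccn4)cc3)c(C)cc2C)n1`: < 1000 nM (a limit)

In a physicochemical assay for solubility, at pH 7.4 (on this read-out higher numbers stand for higher solubility and lower numbers for lower solubility), compound 3 gives no number, only the limit < 1000 nM. Its place on the numbers shown is thus (the limit of < 1000 nM in this assay, at which 2 of the 3 values shown sit).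

In compound 4 `Cc1cc(C)c(-c2ccc(N)nn2)cc1NC(=O)c1ccc(OCc2ccccn2)cc1`, 6-aminopyridazin-3-yl stands in place of 4-methyl-1,3-thiazol-2-yl on an aromatic carbon, ortho to a methyl group and para to a methyl group (6-aminopyridazin-3-yl in place of 4-methyl-1,3-thiazol-2-yl on an aromatic carbon).

Among the compounds with values here, only one measured step bears on this change, and only loosely: an at least 20-fold lower number from compound 1 to compound 2 (1.30 log units; beyond the scatter). That step, methyl in place of hydrogen on an aromatic carbon, was large and lay beyond the scatter. It shows that this assay can move widely on a small exchange within this series, although its group is not the one exchanged here. The whole group changes in the step at hand, so a step upward in this assay beyond the scatter is expected, though with low confidence. The upper reach of that expectation is set by compound 1 at 20000 nM. The expected step is an at least 3.0-fold higher number from compound 3 to compound 4 (0.47 log units; beyond the scatter). Compound 4 is estimated at 3000 nM, with an expected range from 600 nM to 20000 nM.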

Compound 4, solubility: 6000 nM
The estimate for compound 4 lay 2.0-fold (0.30 log units) below the measured number; the range from low to high includes it.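

The change gives an at least 6.0-fold higher number from compound 3 to compound 4 (0.77 log units; beyond the scatter) in this assay, so the group on this aromatic carbon, ortho to a methyl group and para to a methyl group, can be exchanged as a whole with a step beyond the scatter, and in the upward direction. Within the data shown here, the only earlier step, an at least 20-fold lower number from compound 1 to compound 2 (1.30 log units; beyond the scatter), was a methyl in place of hydrogen on an aromatic carbon and ran the other way, so compound 4 adds a measured number at this position, where compound 3 offered only a limit. The step can be read only as a floor because compound 3 stands at a limit: the limit of < 1000 nM in this assay, at which 2 of the 4 values shown sit.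

What the compounds shown leave open is which part of the exchange goes with the step, since the entering 6-aminopyridazin-3-yl differs from 4-methyl-1,3-thiazol-2-yl in ring size, in its hetero atoms and in its amine all at once. Going by these compounds, a plain pyridazin-3-yl without the amine, or a 6-methoxypyridazin-3-yl, would separate the ring from the amine, and the full size of the step stays unknown.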